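A New Substituent on the Shared Core of Compound 1

The source may hold more compounds than are shown below. What is called first, only, known or untested is meant among the compounds shown, and "the series" means these compounds.

Going by the values given here, compound 1 `COc1ccc(-c2nc(/N=C(\N)N(C)C)sc2-c2ccc(OC)cc2)cc1` is the only compound here with an actual number: in a functional assay with Oryctolagus cuniculus as the target (a lower number here means a stronger inhibitor, a higher number a weaker inhibitor), compound 1 gives 37 nM. Compound 2 `COc1ccc(-c2nc(CN)sc2-c2ccc(OC)cc2)cc1` reaches only a limit of the assay, with compound 2 giving > 100 nM. Compound 3 `COc1ccc(-c2nc(C(=O)N=C(N)N)sc2-c2ccc(OC)cc2)cc1` likewise sits at a limit, with compound 3 giving > 100 nM. Both changes from compound 1 weakened inhibition: an at least 2.7-fold higher number from compound 1 to compound 2 (0.43 log units; beyond the scatter) and an at least 2.7-fold higher number from compound 1 to compound 3 (0.43 log units; beyond the scatter). Compound 4 `COc1ccc(-c2nc(C(=O)N3CCCCC3)sc2-c2ccc(OC)cc2)cc1` alters the same group on compound 1: a group of 8 heavy atoms (6 carbon, 1 nitrogen, 1 oxygen; one six-membered non-aromatic ring with 1 hetero atom) in place of a group of 6 heavy atoms (3 carbon, 3 nitrogen; no ring), on an aromatic carbon. Because an at least 2.7-fold higher number from compound 1 to compound 2 (0.43 log units; beyond the scatter) and an at least 2.7-fold higher number from compound 1 to compound 3 (0.43 log units; beyond the scatter) both went toward weaker inhibition, compound 4 is expected to be weaker as well, with the step of an 8.1-fold higher number from compound 1 to compound 4 (0.91 log units; beyond the scatter) likely carrying it to the limit of > 100 nM in this assay, at which 2 of the 3 values shown sit. Compound 4 is therefore estimated at 300 nM, in the range 80 nM to 2000 nM.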

Compound 4, half-maximal inhibitory concentration: > 1000 nM
Compound 4 gave a limit, no number (the forecaster's own chance of this, stated with the estimate: 70%); at least 3.3-fold (0.52 log units) between middle value and limit.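

In this assay, going by these compounds alone, the step to (piperidin-1-yl)carbonyl is the first here that reads as large, where the earlier two could be read only as at least modest: an at least 27-fold higher number from compound 1 to compound 4 (1.43 log units; beyond the scatter). The steps to compound 4 from compound 2 and from compound 3 cannot be read, as both ends of each are limits. The value of compound 4 is itself a limit and not a number, and it is the highest limit seen at this position: the limit of > 1000 nM in this assay, at which 1 of the 4 values shown sits.

From the compounds shown here alone, it remains open whether a carboxylic acid or a smaller amide, such as dimethylaminocarbonyl, would keep any inhibition at this position.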